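A few compounds are considered here, and "the series" means these few. Any claim that something is new, unique, unknown or untested is made for them only; others in the source may bear on it.

Compounds measured:
compound 1 `O=S(=O)(NCCCNCc1ccc(Cl)c(C(F)(F)F)c1)c1cc(C(F)(F)F)cc(C(F)(F)F)c1` — in a functional assay on HT-29 cells (Homo sapiens) for inhibition, read by MTT assay, with a stated time of 72 h (on this read-out higher numbers stand for weaker inhibition of growth and lower numbers for stronger inhibition of growth), compound 1 gives 11000 nM
compound 2 `O=S(=O)(NCCCNCc1ccc(Br)cc1)c1cc(C(F)(F)F)cc(C(F)(F)F)c1` — in this assay compound 2 gives 2200 nM

Among the measured compounds shown here, of these two numbers, compound 2 holds the lower one: the only measured step, a 5.0-fold lower number from compound 1 to compound 2 (0.70 log units; beyond the scatter), separates it from compound 1, which stands beyond the scatter.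

Compound 3 `O=S(=O)(NCCCNCc1cccc2ccccc12)c1cc(C(F)(F)F)cc(C(F)(F)F)c1` departs from compound 2 by naphthalen-1-yl in place of 4-bromophenyl on a saturated chain carbon bound to an amine nitrogen. For the measured compounds named here, no measured step bears on this change: the one step seen, a 5.0-fold lower number from compound 1 to compound 2 (0.70 log units; beyond the scatter), exchanges one substituted phenyl for another and says nothing about replacing a phenyl by a naphthalenyl. That step was modest, which suggests that exchanges at this position move the number by limited amounts, but a single step is a thin basis. Compound 3 is therefore expected to stay near compound 2, the estimated step being a 1.1-fold higher number from compound 2 to compound 3 (0.06 log units; within the scatter). On that basis compound 3 is expected to give 2500 nM, with a range from 700 nM to 9000 nM.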

Compound 3, concentration for 50% growth inhibition: 2600 nM
Compound 3: middle estimate off by 1.0-fold (0.02 log units), on the low side; the measured number falls inside the stated range.
By their numbers in this assay, from the lowest: compounds 2 and 3 (each within the scatter of the next); then compound 1.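

In this assay, the naphthalen-1-yl group, which brings a second six-membered aromatic ring and no bromine, gives a 1.2-fold higher number from compound 2 to compound 3 (0.07 log units; within the scatter), so on a saturated chain carbon bound to an amine nitrogen the numbers do not separate it from 4-bromophenyl. Set against 4-chloro-3-(trifluoromethyl)phenyl, the same group gives a 4.2-fold lower number from compound 1 to compound 3 (0.63 log units; beyond the scatter), which places compound 1 apart from both compound 2 and compound 3 by a modest step. No measurement at hand explains why these groups give these numbers.

Still open, as far as these compounds go, is how an unsubstituted phenyl, a naphthalen-2-yl or a ring carrying a carboxylic acid would fare at this position. Also open, from the compounds shown here alone, is what a longer chain in the shared core would do to the growth inhibition seen with these groups.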